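Halogen swap on the anilino ring: iodo to bromo

The compounds below may be only part of what the source reports. "The series", "measured", "known", "first", "only" and "open" are said of these compounds alone.

Three ureas sharing one core have been measured. Compound 1 `COc1cc(NC(=O)Nc2cc(Nc3ccc(C)c(F)c3)ncn2)cc(OC)c1` gives 38% in a functional assay on NCI-H1581 cells (Homo sapiens) for inhibition, read by MTT assay, with a stated time of 48 h, tested at 10 uM; on this read-out lower numbers stand for less inhibition and higher numbers for more inhibition at the one concentration tested (going by the name of the read-out). Compound 2 `COc1cc(NC(=O)Nc2cc(Nc3cc(F)ccc3OC)ncn2)cc(OC)c1` gives 42.1% in this assay, and compound 3 `COc1cc(NC(=O)Nc2cc(Nc3cc(I)ccc3OC)ncn2)cc(OC)c1` gives 59%. Compound 3 stands highest of the three, with its step to compound 2 and its step to compound 1 both beyond the scatter: a number 16.9 percentage points higher from compound 2 to compound 3 (beyond the scatter), and a number 21 percentage points higher from compound 1 to compound 3 (beyond the scatter). The step of a number 4.1 percentage points higher from compound 1 to compound 2 (within the scatter) is within the scatter.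

Compound 4 `COc1cc(NC(=O)Nc2cc(Nc3cc(Br)ccc3OC)ncn2)cc(OC)c1` has not yet been measured. It differs from compound 3 in one place: bromo in place of iodo on an aromatic carbon. The step that bears most directly on this change is the one from fluoro to iodo, a number 16.9 percentage points higher from compound 2 to compound 3 (beyond the scatter), a modest rise. Bromo is neither of those two halogens, and no step between bromo and iodo is available, so the expectation rests on compound 3 alone, with a slight allowance for a number between the fluoro and iodo results. Compound 4 is therefore expected to give 54% in this assay, in a range from 40% to 66%. The expected step is a number 5 percentage points lower from compound 3 to compound 4 (within the scatter), which is not expected to exceed the scatter.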

Compound 4, a percentage reported as inhibition, at one concentration (the size of the read-out at that concentration, not a potency): 23.1%
Estimate against measurement, compound 4: 30.9 percentage points above, outside the stated range (below it).
By their numbers in this assay, from the lowest: compound 4; then compounds 1 and 2 (each within the scatter of the next); then compound 3.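

In this assay the position para to a methoxy group turns out to be far more sensitive to the choice of halogen than the fluoro and iodo compounds alone could show, with a number 35.9 percentage points lower from compound 3 to compound 4 (beyond the scatter) for the exchange of a single atom. Bromo does not fall between the other two halogens, as the result runs a number 19 percentage points lower from compound 2 to compound 4 (beyond the scatter) and the 5-bromo-2-methoxyphenyl group also trails 3-fluoro-4-methylphenyl, with a number 14.9 percentage points lower from compound 1 to compound 4 (beyond the scatter). Nothing available here bears on what lies behind this order of the halogens.

The compounds shown leave open what chloro would give at this position, and so whether the high value of compound 3 is peculiar to iodo. They also leave open whether a nitrile or an ethynyl group there would behave more like iodo or like bromo.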